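Sulfonyl versus benzoyl on the linker amine

This account rests on a few compounds, and the source may have more. Where it says the series, first, only, none or still open, it means among the compounds named here.

Measured compounds:
compound 1 `O=S(=O)(NCCNc1nccc(-c2c(-c3cccc(F)c3)nc3sccn23)n1)c1ccc(F)cc1`: 9450 nM
compound 2 `O=C(NCCNc1nccc(-c2c(-c3cccc(F)c3)nc3sccn23)n1)c1ccccc1`: 17000 nM

In a functional assay on SK-MEL-28 cells (Homo sapiens) for cytotoxicity, read by MTT assay (a lower number here means a stronger inhibitor, a higher number a weaker inhibitor), compound 2 gives 17000 nM, the highest of the two numbers. Its nearest neighbour is compound 1, where the step of a 1.8-fold higher number from compound 1 to compound 2 (0.26 log units; within the scatter) lies within the scatter, so the two compounds cannot be placed in any order on cytotoxicity.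

Compound 3 `Cc1ccc(S(=O)(=O)NCCNc2nccc(-c3c(-c4cccc(F)c4)nc4sccn34)n2)cc1` is not yet measured. It differs from compound 2 by (4-methylphenyl)sulfonyl in place of benzoyl on an amine nitrogen.

Among the compounds with values here, the one step that bears on this change is the step from compound 1 to compound 2, which replaced a sulfonyl group on the amine nitrogen with benzoyl and gave a 1.8-fold higher number from compound 1 to compound 2 (0.26 log units; within the scatter). Going back to a sulfonyl group, now carrying a methyl instead of fluorine on the ring, is expected to reverse that step at most, so the expected change a 1.8-fold lower number from compound 2 to compound 3 (0.25 log units; within the scatter) stays within the scatter. Compound 3 is therefore estimated at 9500 nM, with a range from 4000 nM to 22000 nM.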

Compound 3, half-maximal inhibitory concentration: > 20000 nM
Compound 3: no number, only a limit; the forecaster's own chance of this, stated with the estimate: 10%; at least 2.1-fold (0.32 log units) between middle value and limit.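

In this assay the reading for compound 3 is a limit of the assay and not a number: the limit of > 20000 nM in this assay, at which 1 of the 3 values shown sits.

Even so, the step with methyl in place of fluoro on an aromatic carbon is readable as an at least 2.1-fold higher number from compound 1 to compound 3 (0.32 log units; beyond the scatter), so the group on the sulfonyl aryl ring changes the reading in this series, which the earlier pair could not show. The step with (4-methylphenyl)sulfonyl in place of benzoyl on the amine nitrogen is an at least 1.1-fold higher number from compound 2 to compound 3 (0.07 log units; that floor lies within the scatter), and since that floor lies within the scatter, these two groups cannot be put in order, while a sulfonyl group on this nitrogen does not by itself keep the lower number.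

As far as these compounds go, the true number of compound 3 stays open, as does whether losing fluoro or gaining methyl drives the step. Also open, from the compounds shown here alone, is how a methoxy group or an unsubstituted phenyl on the sulfonyl, or a longer chain in the linker, would read here.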